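This account rests on a few compounds, and the source may have more. Where it says the series, first, only, none or still open, it means among the compounds named here.

Compound 1 `CCCCCC1(O)C(=O)Nc2ccc(Nc3ccc(C)cc3)cc21` was tested in a functional assay on A549 cells (Homo sapiens) for antiproliferative activity, read by MTT assay, with a stated time of 48 h (on this read-out higher numbers stand for weaker inhibition and lower numbers for stronger inhibition), where compound 1 gives 8100 nM. Compound 2 `CCCCCCC1(O)C(=O)Nc2ccc(Nc3ccc(C)cc3)cc21` differs from compound 1 in one place, (methyl in place of hydrogen on a saturated chain carbon, five bonds along the chain from a saturated ring carbon), and in this assay compound 2 gives 12100 nM; the step is a 1.5-fold higher number from compound 1 to compound 2 (0.17 log units; within the scatter). Compound 3 `CCCCC1(O)C(=O)Nc2ccc(Nc3ccc(C(F)(F)F)cc3)cc21` carries a different core, and how the cores of compound 1 and compound 3 differ is not broken down here. In this assay compound 3 gives 2300 nM, the lowest of the three numbers, with compound 1 nearest and compound 2 furthest. Compound 4 `CCCCCC1(O)C(=O)Nc2ccc(Nc3ccc(C(F)(F)F)cc3)cc21` has not yet been measured. Among the compounds with values here, it differs from compound 3 by methyl in place of hydrogen on a saturated chain carbon, four bonds along the chain from a saturated ring carbon, the same kind of change as the one from compound 1 to compound 2, only here the entering methyl sits four bonds along the chain from a saturated ring carbon rather than five. Compound 4 is expected to move from compound 3 by a 1.4-fold higher number from compound 3 to compound 4 (0.14 log units; within the scatter), a step of about the size seen as a 1.5-fold higher number from compound 1 to compound 2 (0.17 log units; within the scatter), which stayed within the scatter. Compound 4 is therefore estimated at 3200 nM, with a likely range from 1500 nM to 7000 nM.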

Compound 4, half-maximal inhibitory concentration: 2200 nM
Beside the measured number, compound 4's estimate is 1.5-fold (0.16 log units) above it, and the stated range covers the measured number.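

In this assay, methyl in place of hydrogen on a saturated chain carbon gives a 1.0-fold lower number from compound 3 to compound 4 (0.02 log units; within the scatter), and this step and the earlier one on the core of compound 1 do not differ: the same change on two cores in this assay, a 1.5-fold higher number (0.17 log units; within the scatter) from compound 1 to compound 2 and a 1.0-fold lower number (0.02 log units; within the scatter) from compound 3 to compound 4, 1.6-fold (0.19 log units) apart, within the scatter of two such steps This shows that the change carried from one core to the other with no step beyond the scatter on either, though the entering methyl sits four bonds along the chain from a saturated ring carbon in one pair and five in the other. Within the data shown here, it does not show that the same would hold on any further core, since it rests on two pairs alone, and the one step beyond the scatter is a different change, a 3.7-fold lower number from compound 1 to compound 4 (0.57 log units; beyond the scatter), with trifluoromethyl in place of methyl on an aromatic carbon, seen once.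

The compounds shown leave open whether a longer chain on the core of compound 3 stays within the scatter as well. They also leave open how a nitrile or a chlorine in place of the trifluoromethyl would read.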